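The source may hold more compounds than are shown below. What is called first, only, known or untested is meant among the compounds shown, and "the series" means these compounds.

In a functional assay on K562 cells (Homo sapiens) for antiproliferative activity, with a stated time of 72 h (a higher number here means a weaker inhibitor, a lower number a stronger inhibitor), compound 1 `OC[C@H]1O[C@@H](n2cnc3c(NCc4cccc(F)c4)ncnc32)[C@H](O)[C@@H]1O` gives 7600 nM and compound 2 `OC[C@H]1O[C@@H](n2cnc3c(NCc4ccc(Cl)c(Cl)c4)ncnc32)[C@H](O)[C@@H]1O` gives 10800 nM, with a 1.4-fold higher number from compound 1 to compound 2 (0.15 log units; within the scatter). Compound 3 `OC[C@H]1O[C@@H](n2cnc3c(NCc4ccc(F)c(F)c4F)ncnc32)[C@H](O)[C@@H]1O` returns only a limit, > 166000 nM, so it has no exact number. Compound 4 `OC[C@H]1O[C@@H](n2cnc3c(NCc4cccc(O)c4O)ncnc32)[C@H](O)[C@@H]1O` carries one change on the saturated chain carbon: 2,3-dihydroxyphenyl in place of 2,3,4-trifluorophenyl on a saturated chain carbon bound to a nitrogen on an aromatic ring. The two steps into compound 3 bear most directly on this change: an at least 21-fold higher number from compound 1 to compound 3 (1.33 log units; beyond the scatter) and an at least 15-fold higher number from compound 2 to compound 3 (1.18 log units; beyond the scatter), both large. Leaving 2,3,4-trifluorophenyl is therefore expected to lower the number, though perhaps not all the way to the other two values, since 2,3-dihydroxyphenyl is untested here. The expected change is an at least 6.6-fold lower number from compound 3 to compound 4 (0.82 log units; beyond the scatter). For compound 4 the estimate is 25000 nM, with an expected range of 6000 nM to 100000 nM.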

Compound 4, half-maximal inhibitory concentration: 25800 nM
Beside the measured number, compound 4's estimate is 1.0-fold (0.01 log units) below it; measured number inside the range.
By their numbers in this assay, from the lowest: compounds 1 and 2 (each within the scatter of the next); then compound 4. At a limit, above all of these: compound 3.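

In this assay, going by these compounds alone, the earlier compounds at this place carried only halogenated phenyl groups, and 2,3-dihydroxyphenyl, the only group here with hydrogen-bond donors, still gives a measurable number (an at least 6.4-fold lower number from compound 3 to compound 4 (0.80 log units; beyond the scatter)). Compound 3 stands only at a limit of the assay, not at a number: the limit of > 166000 nM in this assay, at which 1 of the 4 values shown sits. The same change still falls short of the other two halogenated groups (a 2.4-fold higher number from compound 2 to compound 4 (0.38 log units; beyond the scatter); a 3.4-fold higher number from compound 1 to compound 4 (0.53 log units; beyond the scatter)), so no halogen is required at this place, though compound 4 is the weaker in both comparisons.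

Going by these compounds, whether a phenyl with a single hydroxyl would match compound 4 stays open. So does the effect of an amine or a carboxylic acid on the phenyl, or of a longer chain leading to it.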